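This account rests on a few compounds, and the source may have more. Where it says the series, first, only, none or still open, it means among the compounds named here.

In an ADME assay (liver) for pharmacokinetics, with Liver microsome (Rattus norvegicus) as the target, read by LC-MS, using microsomes, tested at 2 uM (a higher number here means faster removal of the compound, a lower number slower removal), compound 1 (`Cc1c(C(=O)N[C@@H]2CCCC[C@H]2O)cc(-c2cc(C(F)(F)F)ccc2Cl)n1CC1CCCCC1`) gives 1.32 mL/min/kg and compound 2 (`O=C(N[C@@H]1CCCC[C@H]1O)c1cnc(OC2CCCCC2)c(-c2ccc(Cl)cc2)c1`) gives 0.662 mL/min/kg with the two values within the scatter of each other. Compound 3 (`O=C(N[C@@H]1CCCC[C@H]1O)c1cnc(Oc2ccccc2)c(-c2ccc(Cl)cc2)c1`) differs from compound 2 by one swap (phenyl in place of cyclohexyl on an oxygen on an aromatic ring) with phenyl in place of cyclohexyl on an oxygen on an aromatic ring. Among the measured compounds shown here, no measured pair isolates this swap, so no step beyond the scatter is expected in this assay in either direction. The estimated move (a 1.1-fold lower number from compound 2 to compound 3 (0.04 log units; within the scatter)) is accordingly small. For compound 3 the estimate is 0.6 mL/min/kg with an expected range from 0.25 mL/min/kg to 1.5 mL/min/kg on repeat measurement.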

Compound 3, clearance: 0.353 mL/min/kg
The estimate for compound 3 lay 1.7-fold (0.23 log units) above the measured number, and the stated range covers the measured number.
By their numbers in this assay, from the lowest: compounds 3, 2 and 1 (each within the scatter of the next, the first and the last beyond it).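

In this assay, among the compounds shown here, compound 2 and compound 3 form the only pair that isolates a change at this oxygen, and phenyl in place of cyclohexyl gives a 1.9-fold lower number from compound 2 to compound 3 (0.27 log units; within the scatter) within this pair. At this position, an aromatic ring of carbon and a non-aromatic ring of carbon therefore cannot be told apart in this read-out. Nothing shown bears on the reason for this.

Open, as far as these compounds go, is whether the position stays this flat with a smaller or a longer group, such as methyl or a straight butyl chain. A piperidine ring or a fluorophenyl group on the same oxygen also remains untested in the compounds shown.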